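The compounds below may be only part of what the source reports. "The series", "measured", "known", "first", "only" and "open" are said of these compounds alone.

Measured so far in a functional assay on MCF7 cells (Homo sapiens) for inhibition, read by MTT assay, with a stated time of 3 days; on this read-out lower numbers stand for stronger inhibition and higher numbers for weaker inhibition

Compound 1 `Cc1cc(=O)oc2cc(OCC(=O)NN3C(=O)C=CC3=O)ccc12` gives 2110 nM
Compound 2 `Cc1cc(=O)oc2cc(OCC(=O)Nn3c(=O)[nH]c4ccccc4c3=O)ccc12` gives 1650 nM
Compound 3 `O=c1oc2ccc(S(=O)(=O)N3CCOCC3)cc2cc1Br` gives 13200 nM

Compound 1 and compound 2 lie within the scatter of each other. Compound 3 at 13200 nM has the highest number of the three and is the weakest, beyond the scatter from both of the others.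

Compound 4 `O=c1oc2ccc(S(=O)(=O)N3CCCCC3)cc2cc1Br` keeps the core of compound 3 and carries piperidin-1-yl in place of morpholin-4-yl on a sulfonyl sulfur. Both groups are six-membered non-aromatic rings. Among the measured compounds shown here, no two measured compounds differ in only one place, so the data give no direct measure of such a swap. The estimate therefore starts from compound 3 at 13200 nM and allows only a small shift toward a lower number in this assay. The expected change is a 1.5-fold lower number from compound 3 to compound 4 (0.17 log units; within the scatter) and is not expected to exceed the scatter. Compound 4 is estimated at 9000 nM with an expected range from 3000 nM to 27000 nM in this test.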

Compound 4, half-maximal inhibitory concentration: 2070 nM
The estimate for compound 4 lay 4.3-fold (0.64 log units) above the measured number, outside the stated range (below it).
By their numbers in this assay, from the lowest: compounds 2, 4 and 1 (each within the scatter of the next); then compound 3.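

In this assay, among the compounds shown here, this is the first direct comparison at this place, and it shows that the choice of ring on the sulfonyl sulfur matters: piperidin-1-yl in place of morpholin-4-yl gives a 6.4-fold lower number from compound 3 to compound 4 (0.80 log units; beyond the scatter). Both groups are six-membered non-aromatic rings with the same count of heavy atoms, and they differ in that a carbon of piperidin-1-yl stands where morpholin-4-yl has its oxygen. No measurement at hand says why the step has this size.

The compounds shown leave open how other groups on the sulfonyl sulfur would read, such as pyrrolidin-1-yl, piperazin-1-yl or an open-chain diethylamino group. They also leave open whether the same exchange gives a similar step when the bromine on the shared core is replaced by hydrogen.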